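The compounds below may be only part of what the source reports. "The series", "measured", "known", "first", "only" and "open" are said of these compounds alone.

- compound 1 `COc1cc(C(=O)c2ccc(OC)c(O)c2OC)cc(OC)c1O`: 100000 nM
- compound 2 `COc1cc(C(=O)c2ccc3c(c2)oc(=O)n3S(C)(=O)=O)cc(OC)c1OC`: 5110 nM

In a functional assay on SK-MEL-2 cells (Homo sapiens) for cytotoxicity, read by sulforhodamine B assay, with a stated time of 48 h (on this read-out lower numbers stand for stronger inhibition of growth and higher numbers for weaker inhibition of growth), compound 1 has the higher number of the two, and its gap to compound 2 lies beyond the scatter. Compound 3 `COc1ccc(C(=O)c2cc(OC)c(OC)c(OC)c2)c(OC)c1O` has not yet been measured. It differs from compound 1 in one place: methyl in place of hydrogen on an oxygen on an aromatic ring. Put simply, a hydroxy becomes a methoxy.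

Among the measured compounds shown here, no measured pair shows this change on its own, so any expectation is loose. For the measured compounds named here, the only guide is compound 2 at 5110 nM, which has a methoxy at the matching place, although it also differs from compound 3 elsewhere. On that slim evidence, stronger inhibition of growth is expected in this assay, by more than the scatter. The expected size of the change is a 50-fold lower number from compound 1 to compound 3 (1.70 log units; beyond the scatter). For compound 3 the estimated value is 2000 nM, with an expected range from 200 nM to 20000 nM.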

Compound 3, concentration for 50% growth inhibition: 26.6 nM
For compound 3 the middle estimate is 75-fold (1.88 log units) above the measured one; measured number outside the range, below it.
By their numbers in this assay, from the lowest: compound 3; then compound 2; then compound 1.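

Read in this assay the swap of one hydroxy for a methoxy gives a 3800-fold lower number from compound 1 to compound 3 (3.58 log units; beyond the scatter) and so shows that this one oxygen on an aromatic ring is a highly sensitive place, where a single added methyl greatly strengthens inhibition of growth. Compound 1 and compound 2 differ in more than one place, so they could not show this, whereas the new pair isolates the change: everything else stays the same, including the other hydroxy, which compound 3 still carries. Nothing at hand explains why one methyl has so large an effect here.

Going by these compounds, it remains open how much room this oxygen offers, for instance whether a longer chain such as ethyl in place of the methyl would keep the strong inhibition, or whether an amine in place of the oxygen group would lose it. The remaining hydroxy of compound 3 is also untested on its own, so it is unclear whether turning it into a methoxy as well would strengthen inhibition further, leave it unchanged or weaken it.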